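The compounds below may be only part of what the source reports. "The series", "measured", "known", "first", "only" and "open" are said of these compounds alone.

Compound 1 `Cc1cc(Nc2nc(NCc3ccc(F)cc3)nc3ccccc23)n[nH]1` gives 20 nM in an assay for inhibition of high affinity nerve growth factor receptor (Homo sapiens), read by HTRF, with a stated time of 30 min, in the presence of a further agent that is not named here; on this read-out higher numbers stand for weaker inhibition and lower numbers for stronger inhibition; compound 2 `Cc1cc(Nc2nc(NCc3ccccc3F)nc3ccccc23)n[nH]1` gives 110 nM.

Of the two numbers, compound 2 stands highest, set apart from compound 1 by a 5.5-fold higher number from compound 1 to compound 2 (0.74 log units; beyond the scatter). Compound 3 `Cc1cc(Nc2nc(NCc3ccc(F)cc3F)nc3ccccc23)n[nH]1` differs from compound 2 by fluoro in place of hydrogen on an aromatic carbon, that is 2-fluorophenyl becoming 2,4-difluorophenyl. No measured step adds a fluoro in this way; the one step shown only moves it. Still, a modest lowering is expected because compound 1 gives 20 nM with fluoro at that same position. Compound 3 is therefore estimated at 50 nM, between 15 nM and 160 nM, an expected step of a 2.2-fold lower number from compound 2 to compound 3 (0.34 log units; beyond the scatter).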

Compound 3, half-maximal inhibitory concentration: 200 nM
Beside the measured number, compound 3's estimate is 4.0-fold (0.60 log units) below it; the whole stated range lies below it.
By their numbers in this assay, from the lowest: compound 1; then compounds 2 and 3 (each within the scatter of the next).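

With the 2-fluoro group in place, adding fluoro para to a large group to give 2,4-difluorophenyl does not restore the stronger inhibition of compound 1: this assay shows a 1.8-fold higher number from compound 2 to compound 3 (0.26 log units; within the scatter), so this change has no effect beyond the scatter here. Adding the 2-fluoro group to the 4-fluorobenzyl compound instead gives a 10-fold higher number from compound 1 to compound 3 (1.00 log units; beyond the scatter), so the low number of compound 1 does not survive that addition. Nothing given here explains this result. Going by these compounds, it remains open how a chloro or methoxy group would behave at this position, and where the unsubstituted benzyl compound would stand.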